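The compounds below may be only part of what the source reports. "The series", "measured", "known", "first", "only" and "open" are said of these compounds alone.

Measured compounds:
- compound 1 `O=C(CCCCCCNC(=O)C(O)(O)C(F)(F)F)Nc1cccc(Br)c1`: 3060 nM
- compound 2 `COc1cc(NC(=O)CCCCCCNC(=O)C(O)(O)C(F)(F)F)cc(OC)c1OC`: 14100 nM
- compound 3 `CC(C)(C)C(O)(O)C(=O)NCCCCCC(=O)Nc1ccccc1`: 54400 nM

These three compounds were tested in a functional assay on HCT-116 cells (Homo sapiens) for inhibition, read by colorimetric assay, with a stated time of 3 days; on this read-out lower numbers stand for stronger inhibition and higher numbers for weaker inhibition. Compound 1 gives 3060 nM, the lowest number of the three and therefore the strongest inhibition seen so far. Compound 2 comes nearest, and its gap to compound 1 lies beyond the scatter. Compound 3 lies furthest away, also beyond the scatter.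

The next compound, compound 4 `O=C(CCCCCCNC(=O)C(O)(O)C(F)(F)F)Nc1nc2ccccc2o1`, keeps the core of compound 1 and changes only the group on the amide-type nitrogen: 1,3-benzoxazol-2-yl in place of 3-bromophenyl on an amide-type nitrogen. Among the compounds with values here, nothing among the measured compounds shows what such an exchange does in this assay, so the expectation rests on compound 1 alone. The step of a 1.6-fold higher number from compound 1 to compound 4 (0.21 log units; within the scatter) is expected to be small, most likely not beyond the scatter, with a slight lean toward a higher number. Compound 4 is therefore estimated at 5000 nM in this assay, within a range from 1500 nM to 20000 nM.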

Compound 4, half-maximal inhibitory concentration: 3450 nM
Beside the measured number, compound 4's estimate is 1.4-fold (0.16 log units) above it; measured number inside the range.
By their numbers in this assay, from the lowest: compounds 1 and 4 (each within the scatter of the next); then compound 2; then compound 3.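

In this assay, putting 1,3-benzoxazol-2-yl in place of 3-bromophenyl on an amide-type nitrogen amounts to a 1.1-fold higher number from compound 1 to compound 4 (0.05 log units; within the scatter) and so gives no difference that can be told from the scatter. Within the data shown here, this is the first pair differing in one place, and it shows that this nitrogen can carry a group with more heavy atoms, no bromine and hydrogen-bond acceptors, which 3-bromophenyl lacks, while the number stays within the scatter. No evidence is at hand on what lies behind this result.

Still open, going by these compounds, is how the assay would respond to a cyclohexyl group, or a phenyl ring carrying a carboxylic acid, on this nitrogen. Also open, on these data alone, is whether these two groups would still read alike with a longer chain in the shared core.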